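The source may report more compounds than this note shows. Statements on the series, on what has been measured and on what is new or still open speak of the compounds shown alone.

Measured so far in a functional assay on Jurkat cells (Homo sapiens) for inhibition; a lower number here means a stronger inhibitor, a higher number a weaker inhibitor:
compound 1, `C[C@H](NC(=O)C(=O)Nc1ccccn1)C(=O)N[C@@H](CC(=O)O)C(=O)COc1c(F)c(F)cc(F)c1F`, gives 1040 nM
compound 2, `C[C@H](NC(=O)C(=O)Nc1ccccc1F)C(=O)N[C@@H](CC(=O)O)C(=O)COc1c(F)c(F)cc(F)c1F`, gives 160 nM
compound 3, `C[C@H](NC(=O)C(=O)Nc1ccccc1C(F)(F)F)C(=O)N[C@@H](CC(=O)O)C(=O)COc1c(F)c(F)cc(F)c1F`, gives 61 nM

Compound 3 holds the lowest number of the three in this assay. Compound 2 sits nearest, a 2.6-fold lower number from compound 2 to compound 3 (0.42 log units; beyond the scatter), and compound 1 furthest, a 17-fold lower number from compound 1 to compound 3 (1.23 log units; beyond the scatter). The remaining step, a 6.5-fold lower number from compound 1 to compound 2 (0.81 log units; beyond the scatter), completes the picture: every change so far sits on the group carried by the amide-type nitrogen, and each of the three moved the number beyond the scatter.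

Compound 4, `C[C@H](NC(=O)C(=O)Nc1cccc2ccccc12)C(=O)N[C@@H](CC(=O)O)C(=O)COc1c(F)c(F)cc(F)c1F`, continues at the same place: naphthalen-1-yl in place of 2-(trifluoromethyl)phenyl on an amide-type nitrogen. The steps from compound 1 to compound 3 and from compound 2 to compound 3 bear on it only loosely, since each swapped the group on a single ring, whereas here a second fused ring enters and the trifluoromethyl leaves. Going by the values given here, no measured pair contains a bicyclic group at this nitrogen, so the direction is not fixed by the data, though a move beyond the scatter in either direction would fit the pattern seen in this assay so far.

Compound 4 is expected at about 60 nM. For compound 4 the expected range runs from 15 nM to 250 nM. The expected step is a 1.0-fold lower number from compound 3 to compound 4 (0.01 log units; within the scatter), essentially flat, with wide uncertainty.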

Compound 4, half-maximal inhibitory concentration: 86 nM
Estimate against measurement, compound 4: 1.4-fold (0.16 log units) below, and the stated range covers the measured number.
By their numbers in this assay, from the lowest: compounds 3, 4 and 2 (each within the scatter of the next, the first and the last beyond it); then compound 1.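

In this assay, going by these compounds alone, the group on the amide-type nitrogen accepts a second fused ring: naphthalen-1-yl, which carries no fluorine, gives the first steps at this place to stay within the scatter, with a 1.4-fold higher number from compound 3 to compound 4 (0.15 log units; within the scatter) and a 1.9-fold lower number from compound 2 to compound 4 (0.27 log units; within the scatter) in the same sentence of the record. Only the pyridin-2-yl group stands apart, with a 12-fold lower number from compound 1 to compound 4 (1.08 log units; beyond the scatter) and so the naphthalen-1-yl group falls on the same side of that gap as the 2-fluorophenyl and 2-(trifluoromethyl)phenyl groups. Nothing measured here speaks to the reason for this flat stretch or for that gap.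

Open, as far as these compounds go, is how a plain phenyl group, or a phenyl group carrying a methoxy or a carboxylic acid, would read at this nitrogen, and whether it would fall with the three low compounds or with the pyridin-2-yl compound. Also open, from the compounds shown here alone, is whether a quinolinyl group, which puts a ring nitrogen into a fused system, would keep the numbers of the naphthalen-1-yl compound or move toward those of the pyridin-2-yl compound.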